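Moving a Fluorine: From Compound 2 to Compound 3

A few compounds are considered here, and "the series" means these few. Any claim that something is new, unique, unknown or untested is made for them only; others in the source may bear on it.

Compound 1 `O=C(Nc1ccccc1F)Nc1cc2ncncc2cc1OCc1ccccc1`: 4500 nM
Compound 2 `O=C(Nc1cccc(F)c1)Nc1cc2ncncc2cc1OCc1cccc(Cl)c1`: 7800 nM

In a functional assay on GBM2 cells (Homo sapiens) for antiproliferative activity, read by WST assay, with a stated time of 72 h (a lower number here means a stronger inhibitor, a higher number a weaker inhibitor), compound 2 at 7800 nM stands within the usual scatter of compound 1 at 4500 nM. Compound 3 `O=C(Nc1ccccc1F)Nc1cc2ncncc2cc1OCc1cccc(Cl)c1` is not yet measured. It differs from compound 2 by one swap, (2-fluorophenyl in place of 3-fluorophenyl on an amide-type nitrogen), with 2-fluorophenyl in place of 3-fluorophenyl on an amide-type nitrogen. Compound 1 carries 2-fluorophenyl too and gives 4500 nM, so no change beyond the scatter is expected in this assay. The expected step is small, a 1.4-fold lower number from compound 2 to compound 3 (0.15 log units; within the scatter). For compound 3 the estimate is 5500 nM, with an expected range of 2500 nM to 12000 nM.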

Compound 3, half-maximal inhibitory concentration: 4400 nM
Compound 3: the middle estimate sits 1.3-fold (0.10 log units) above what was measured, and the stated range covers the measured number.
By their numbers in this assay, from the lowest: compounds 3, 1 and 2 (each within the scatter of the next).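

In this assay the fluorine swap, 2-fluorophenyl in place of 3-fluorophenyl on the amide-type nitrogen, gives a 1.8-fold lower number from compound 2 to compound 3 (0.25 log units; within the scatter) and so shows no readable effect of where the fluorine sits. The first direct test of the chloro group, chloro in place of hydrogen on an aromatic carbon, gives a 1.0-fold lower number from compound 1 to compound 3 (0.01 log units; within the scatter) and likewise shows no readable effect. No measurement on hand explains why these two changes leave the number in place. Going by these compounds, whether a larger change on this phenyl ring, such as a methoxy group or an amine in place of the fluorine, would move the number remains open.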